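Replacing a methoxy with a hydroxypyrrolidine amide

The source may report more compounds than this note shows. Statements on the series, on what has been measured and on what is new or still open speak of the compounds shown alone.

Compound 1 `COc1ccccc1-n1cc(COc2c(/C=C\C(=O)O)ccc(OC)c2CC=C(C)C)nn1` was tested in a functional assay on A-431 cells (Homo sapiens) for cytotoxicity, read by MTT assay, with a stated time of 24 h (a lower number here means a stronger inhibitor, a higher number a weaker inhibitor), and gives 32600 nM. Among the two numbers available it sits at the upper end, separated from compound 2 `COc1cccc(-n2cc(COc3c(/C=C\C(=O)O)ccc(OC)c3CC=C(C)C)nn2)c1` by only a 1.4-fold lower number from compound 1 to compound 2 (0.15 log units; within the scatter), which lies within the scatter of this kind of measurement. In this assay compound 2 gives 23200 nM. A third member of the series, compound 3 `COc1ccc(-n2cc(COc3c(/C=C\C(=O)O)ccc(OC)c3CC=C(C)C)nn2)cc1`, carries no number, as in this assay compound 3 gives "not determined" (no result reported).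

Compound 4 `COc1ccc(/C=C\C(=O)O)c(OCc2cn(-c3ccccc3C(=O)N3CCC(O)C3)nn2)c1CC=C(C)C` has not yet been measured. It differs from compound 1 in one place: (3-hydroxypyrrolidin-1-yl)carbonyl in place of methoxy on an aromatic carbon. Within the data shown here, the only measured step, from compound 1 to compound 2, moves a methoxy around the same ring without adding atoms, and it stays within the scatter. Among the measured compounds shown here, no measured step replaces the methoxy with a larger group, so the change in compound 4 is not directly covered by the data. The small effect of the step from compound 1 to compound 2 suggests that this part of the molecule tolerates change, and compound 4 is therefore expected to stay close to compound 1, with a step of a 1.2-fold lower number from compound 1 to compound 4 (0.07 log units; within the scatter). Compound 4 is estimated to give 28000 nM in this assay, within a range from 8000 nM to 90000 nM.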

Compound 4, half-maximal inhibitory concentration: 31500 nM
Estimate against measurement, compound 4: 1.1-fold (0.05 log units) below; the measured number falls inside the stated range.
By their numbers in this assay, from the lowest: compounds 2, 4 and 1 (each within the scatter of the next).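

In this assay, (3-hydroxypyrrolidin-1-yl)carbonyl in place of methoxy on the aromatic carbon gives a 1.0-fold lower number from compound 1 to compound 4 (0.01 log units; within the scatter), so the two numbers cannot be told apart. The earlier step only moved a methoxy around the ring, whereas this one puts a group of 8 heavy atoms, with a five-membered non-aromatic ring and a hydrogen-bond donor, where a group of 2 heavy atoms stood, showing that this position accepts a much larger group in this assay without a readable difference. No measurement at hand accounts for this result.

The compounds shown leave open whether the hydroxyl on the pyrrolidine matters, which the plain pyrrolidin-1-ylcarbonyl group would test. They also leave open whether a different kind of group at this position, such as a primary amine or a morpholine amide, would read the same.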